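The source may report more compounds than this note shows. Statements on the series, on what has been measured and on what is new or still open speak of the compounds shown alone.

Compound 1 `Cc1ccc(CN2CCC(NC(=O)NCc3ccc(-c4ccc(F)cc4)cc3)CC2)cc1`: 6.71 in an in vitro functional assay on HEK293 cells for antagonist activity at melanin-concentrating hormone receptor 1 (Homo sapiens), read by GTPgammaS binding, with a stated time of 45 min; a lower number here means a less potent compound, a higher number a more potent compound, by a factor of ten per unit of this negative logarithm
Compound 2 `Cc1ccc(CN2CCC(CCN(Cc3ccc(-c4ccc(F)cc4)cc3)C(=O)NC(C)C)CC2)cc1`: 6.42 in this assay
Compound 3 `COc1ccc(-c2ccc(CN(CCC3CCN(Cc4ccc(C)cc4)CC3)C(=O)NC(C)C)cc2)cc1`: 6.34 in this assay

Compound 3 stands lowest of these three numbers. Its nearest neighbour is compound 2, whose number is higher by an amount within the scatter, so the two cannot be told apart; compound 1 lies further off, higher by an amount beyond the scatter.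

Compound 4 `Cc1ccc(CN2CCC(CCN(Cc3ccc(-c4cccc(C#N)c4)cc3)C(=O)NC(C)C)CC2)cc1` has not yet been measured. It differs from compound 3 in one place: 3-cyanophenyl in place of 4-methoxyphenyl on an aromatic carbon. Within the data shown here, the only measured step at the same place is a number 0.08 log units lower from compound 2 to compound 3 (within the scatter), where one group gave way to another and the number hardly moved. Among the measured compounds shown here, no measured step introduces a nitrile, so the reach of that change is unknown here. The expected step is a number 0.06 log units higher from compound 3 to compound 4 (within the scatter) in this assay, with no change beyond the scatter as the likeliest outcome. Compound 4 is estimated at 6.4, with a range from 5.9 to 6.9.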

Compound 4, negative logarithm of the antagonist equilibrium constant: 6
Compound 4: middle estimate off by 0.40 log units, on the high side; measured number inside the range.
By their numbers in this assay, from the lowest: compound 4; then compounds 3, 2 and 1 (each within the scatter of the next, the first and the last beyond it).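

Until now this position looked undemanding, as 4-fluorophenyl and 4-methoxyphenyl could not be told apart. The change to 3-cyanophenyl gives a number 0.34 log units lower from compound 3 to compound 4 (beyond the scatter) and a number 0.42 log units lower from compound 2 to compound 4 (beyond the scatter) in this assay and so shows that the group held here can affect the number, though only modestly. The change moves the substituent on the ring and replaces it with a nitrile at the same time, and nothing available explains the lower number.

The compounds shown therefore cannot separate the effect of the nitrile from the effect of where it sits on the ring. A 4-cyanophenyl or 3-methoxyphenyl group would address that question, while an unsubstituted phenyl or a 4-aminophenyl group would test how far the position tolerates other changes.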